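Thiosemicarbazone series: pyrrole in place of hydroxyphenyl

The compounds below may be only part of what the source reports. "The series", "measured", "known", "first", "only" and "open" are said of these compounds alone.

Measured so far in a functional assay on PC-3 cells (Homo sapiens) for inhibition, read by sulforhodamine B assay, with a stated time of 48 h; a lower number here means a stronger inhibitor of growth, a higher number a weaker inhibitor of growth: compound 1 `CC1=CC[C@H](C(C)(C)NC(=S)N/N=C/c2ccc(O)cc2)CC1` gives 53800 nM. Compound 3 `COc1cc(/C=N/NC(=S)NC(C)(C)[C@H]2CC=C(C)CC2)ccc1O` gives 8300 nM. Compound 2 `CC1=CC[C@H](C(C)(C)NC(=S)N/N=C/c2ccc(N(C)C)cc2)CC1` gives only a limit, < 700 nM, in this assay.

Compound 1 has the highest of the two plain numbers; its nearest neighbour is compound 3, with a 6.5-fold lower number from compound 1 to compound 3 (0.81 log units; beyond the scatter). Compound 4 `CC1=CC[C@H](C(C)(C)NC(=S)N/N=C/c2ccc[nH]2)CC1` differs from compound 1 by 1H-pyrrol-2-yl in place of 4-hydroxyphenyl on a carbon with a double bond to nitrogen. Both measured steps keep the aromatic ring and add a group to it: an at least 76-fold lower number from compound 1 to compound 2 (1.88 log units; beyond the scatter) is large, a 6.5-fold lower number from compound 1 to compound 3 (0.81 log units; beyond the scatter) is modest. For the measured compounds named here, neither exchanges the ring itself, so no measured step bears directly on this change; both only lower the number. Compound 4 is therefore expected to show a 2.2-fold lower number from compound 1 to compound 4 (0.33 log units; beyond the scatter), with wide uncertainty. The estimate for compound 4 in this assay is 25000 nM, between 5000 nM and 80000 nM.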

Compound 4, concentration for total growth inhibition: > 100000 nM
Compound 4: a limit, no number (the forecaster's own chance of this, stated with the estimate: 5%); middle value at least 4.0-fold (0.60 log units) away from the limit.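

Compound 4 gives a limit in this assay, not a number: the limit of > 100000 nM in this assay, at which 1 of the 4 values shown sits. Exchanging the ring on this carbon gives an at least 1.8-fold higher number from compound 1 to compound 4 (0.26 log units; that floor lies within the scatter). Unlike the two changes that keep the six-membered ring, this exchange shows no lowering of the number, so 1H-pyrrol-2-yl offers no gain over 4-hydroxyphenyl here.

The compounds shown do not separate the effect of the five-membered ring from that of losing the hydroxy group, and the full size of the step remains unknown. Plain phenyl, or a pyrrole carrying dimethylamino, would address the first question.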